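The source may hold more compounds than are shown below. What is called first, only, known or untested is meant among the compounds shown, and "the series" means these compounds.

Measured so far in a functional assay on HL-60 cells (Homo sapiens) for cytotoxicity, read by MTT assay, with a stated time of 48 h; a higher number here means a weaker inhibitor, a lower number a stronger inhibitor:
Compound 1 `Fc1cccc(-c2nc(Nc3ccccc3)c3cc(F)ccc3n2)c1` gives 48300 nM.
Compound 2 `COc1ccccc1Nc1nc(-c2cccc(F)c2)nc2ccc(F)cc12` gives only a limit of the assay, > 50000 nM.
Compound 3 `Fc1cccc(-c2nc(Nc3ccccc3Br)c3cc(F)ccc3n2)c1` gives only a limit of the assay, > 50000 nM.

Within the data shown here, compound 1 holds the only true number here; the values of compound 2 and compound 3 are limits, so compound 1 is the one point to read from, and it already sits close to the top of the measured range. Compound 4 `Oc1cccc(Nc2nc(-c3cccc(F)c3)nc3ccc(F)cc23)c1` differs from compound 1 by hydroxy in place of hydrogen on an aromatic carbon. The two measured steps from compound 1 both alter the same anilino ring: an at least 1.0-fold higher number from compound 1 to compound 2 (0.01 log units; that floor lies within the scatter), and an at least 1.0-fold higher number from compound 1 to compound 3 (0.01 log units; that floor lies within the scatter). Both only reach (the limit of > 50000 nM in this assay, at which 2 of the 3 values shown sit), so neither shows a gain. A hydroxy on that ring is expected to do much the same, a step of a 1.2-fold higher number from compound 1 to compound 4 (0.09 log units; within the scatter). Compound 4 is therefore estimated at 60000 nM, between 20000 nM and 150000 nM, with a real chance that only a limit is reported.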

Compound 4, half-maximal inhibitory concentration: > 50000 nM
Compound 4 gave a limit, no number (the forecaster's own chance of this, stated with the estimate: 65%); the middle value is on the limit's open side.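

Hydroxy, meta to a large group, puts a hydrogen-bond donor on the anilino ring, and in this assay this gives an at least 1.0-fold higher number from compound 1 to compound 4 (0.01 log units; that floor lies within the scatter). The value of compound 4 is only a limit, so that step is a floor and shows no gain over compound 1. All three ring changes shown here end the same way: the limit of > 50000 nM in this assay, at which 3 of the 4 values shown sit.

From the compounds shown here alone, the steps among compound 2, compound 3 and compound 4 cannot be read, and how far each lies past the limit stays unknown. Going by these compounds, whether an amine or a carboxylic acid on this ring would lower the number remains open.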